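Shortening the Side Chain of Compound 1

A few compounds are considered here, and "the series" means these few. Any claim that something is new, unique, unknown or untested is made for them only; others in the source may bear on it.

Of the compounds shown here, three sharing one core have been measured in a functional assay on K562 cells (Homo sapiens) for inhibition, read by MTT assay, with a stated time of 72 h; a higher number here means a weaker inhibitor, a lower number a stronger inhibitor. Compound 1 `CCCCCCCCCCCCc1ccc(C(=O)/C=C/C(=O)O)cc1` gives 4010 nM, the lowest number of the three. Compound 2 `CC(C)c1cc(C(C)C)c(C(=O)/C=C/C(=O)O)c(C(C)C)c1` gives 4670 nM, which lies within the usual scatter of the value for compound 1, so the two cannot be ranked. Compound 3 `O=C(O)/C=C/C(=O)c1ccc(Cl)cc1Cl` gives 58500 nM, a weaker result that lies beyond the scatter. Compound 4 `CCCCc1ccc(C(=O)/C=C/C(=O)O)cc1` has not been measured; it differs from compound 1 in one place: hydrogen in place of octyl on a saturated chain carbon, four bonds along the chain from an aromatic carbon. Because compound 3, which also carries no long chain, gives 58500 nM, a move toward a higher number is expected, though smaller than that gap. For compound 4 the expected step is a 3.7-fold higher number from compound 1 to compound 4 (0.57 log units; beyond the scatter). Compound 4 is estimated at 15000 nM, between 5000 nM and 45000 nM.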

Compound 4, half-maximal inhibitory concentration: 4950 nM
Beside the measured number, compound 4's estimate is 3.0-fold (0.48 log units) above it; the whole stated range lies above it.
By their numbers in this assay, from the lowest: compounds 1, 2 and 4 (each within the scatter of the next); then compound 3.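

In this assay, hydrogen in place of octyl on this saturated chain carbon gives a 1.2-fold higher number from compound 1 to compound 4 (0.09 log units; within the scatter), so the two compounds cannot be ranked. This single change shows that the octyl part of the chain of compound 1 is not needed to keep the number in this range, which compounds differing in more than one place could not show. Nothing measured here gives a reason for this result. Still open, on these data alone, is whether the chain remaining in compound 4 matters at all, and whether a longer chain or an amine in its place would shift the number beyond the scatter.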